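The compounds below may be only part of what the source reports. "The series", "measured", "known", "first", "only" and "open" are said of these compounds alone.

Measured compounds:
compound 1, `Cc1ccc2oc(-c3ccc(NC(=O)CN4CCN(CCN(C)C)CC4)cc3)nc2c1`, 1630 nM;
compound 2, `Cc1cc(-c2nc3cc(Cl)ccc3o2)ccc1NC(=O)CN1CCN(CCN(C)C)CC1`, 13500 nM;
compound 3, `Cc1ccc2oc(-c3ccc(NC(=O)CN4CCN(CCCN(C)C)CC4)cc3)nc2c1`, 1810 nM.

All three were tested in a functional assay on C6 cells (Rattus norvegicus) for cytotoxicity, read by MTT assay, with a stated time of 24 h; on this read-out higher numbers stand for weaker inhibition and lower numbers for stronger inhibition. Compound 2 gives the highest number of the three, with compound 3 and compound 1 both well below it; the difference between the core of compound 2 and the core of compound 1 is not broken down here. Compound 1 and compound 3 share a core and differ by (dimethylamino)methyl in place of dimethylamino on a saturated chain carbon, two bonds along the chain from an amine nitrogen in a ring, a change that gave a 1.1-fold higher number from compound 1 to compound 3 (0.05 log units; within the scatter). Compound 4, `Cc1cc(-c2nc3cc(Cl)ccc3o2)ccc1NC(=O)CN1CCN(CCCN(C)C)CC1`, has not yet been measured; it differs from compound 2 by (dimethylamino)methyl in place of dimethylamino on a saturated chain carbon, two bonds along the chain from an amine nitrogen in a ring, the same change at the same place. Because that change gave a 1.1-fold higher number from compound 1 to compound 3 (0.05 log units; within the scatter) in the other pair, the step from compound 2 to compound 4 is expected to be a 1.1-fold higher number from compound 2 to compound 4 (0.03 log units; within the scatter). Compound 4 is therefore estimated at 14500 nM, with an expected range from 6000 nM to 35000 nM.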

Compound 4, half-maximal inhibitory concentration: 14200 nM
For compound 4 the middle estimate is 1.0-fold (0.01 log units) above the measured one; the measured number falls inside the stated range.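

In this assay, putting (dimethylamino)methyl in place of dimethylamino on a second core gave a 1.1-fold higher number from compound 2 to compound 4 (0.02 log units; within the scatter). Set beside the earlier pair, the change carries over in the sense that it stays within the scatter on both cores: the same change on two cores in this assay, a 1.1-fold higher number (0.05 log units; within the scatter) from compound 1 to compound 3 and a 1.1-fold higher number (0.02 log units; within the scatter) from compound 2 to compound 4, 1.1-fold (0.02 log units) apart, within the scatter of two such steps

This shows that the change can be moved between these two cores without a measurable shift in this cytotoxicity read-out; it does not show that the same would hold on any other core or in any other assay, and two pairs make no rule for the series.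

The compounds shown leave open whether a longer chain, such as 4-(dimethylamino)butyl, or a morpholine in place of the dimethylamino end would behave the same way. Also open, as far as these compounds go, is which of the differences between the core of compound 1 and the core of compound 2 goes with the gap in their numbers.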